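This account rests on a few compounds, and the source may have more. Where it says the series, first, only, none or still open, it means among the compounds named here.

Compound 1 `COc1cccc(C(=O)NO)c1` is a small aromatic hydroxamic acid; in an ADME assay on Huh-7 cells (Homo sapiens) for cytotoxicity, read by MTT assay, with a stated time of 72 h (on this read-out lower numbers stand for higher toxicity in this test and higher numbers for lower toxicity in this test), compound 1 gives 570000 nM. Compound 2 `O=C(NO)c1cccc(Cl)c1` differs from it by chloro in place of methoxy on an aromatic carbon, and in this assay compound 2 gives 120000 nM. That single change produced a 4.8-fold lower number from compound 1 to compound 2 (0.68 log units; beyond the scatter).

Compound 3 `COc1cc(C)ccc1C(=O)NO` has a different core from compound 1; the difference between the two cores is not broken down here. In this assay compound 3 gives 900000 nM. Compound 4 `Cc1ccc(C(=O)NO)c(Cl)c1` carries the same kind of change as that from compound 1 to compound 2, namely (chloro in place of methoxy on an aromatic carbon). The surroundings differ: in compound 4 the chloro sits ortho to a hydroxycarbamoyl group and meta to a methyl group, whereas in compound 2 it is meta to a hydroxycarbamoyl group. Because the earlier change gave a 4.8-fold lower number from compound 1 to compound 2 (0.68 log units; beyond the scatter), a step of about the same size, a 4.5-fold lower number from compound 3 to compound 4 (0.65 log units; beyond the scatter), is expected. Compound 4 is therefore estimated at 200000 nM, within 80000 nM to 500000 nM.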

Compound 4, half-maximal cytotoxic concentration: 140000 nM
Beside the measured number, compound 4's estimate is 1.4-fold (0.15 log units) above it; the range from low to high includes it.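

Putting chloro in place of methoxy on the second core gives a 6.4-fold lower number from compound 3 to compound 4 (0.81 log units; beyond the scatter), so the number drops on this core as well. In this assay the step carried over from one core to the other at much the same size: the same change on two cores in this assay, a 4.8-fold lower number (0.68 log units; beyond the scatter) from compound 1 to compound 2 and a 6.4-fold lower number (0.81 log units; beyond the scatter) from compound 3 to compound 4, 1.4-fold (0.13 log units) apart, within the scatter of two such steps. Among the compounds shown here, this rests on only two pairs, so it shows that the change behaved alike on these two cores in this one cell test, but it does not show that it would do so on other cores, or why the number drops.

As far as these compounds go, it remains open whether an amine or a carboxylic acid in the same place would lower the number, raise it or leave it unchanged. From the compounds shown here alone, a longer chain such as ethoxy is equally open.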